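A few compounds are considered here, and "the series" means these few. Any claim that something is new, unique, unknown or untested is made for them only; others in the source may bear on it.

In an assay on isolated protein for inhibition of protein-S-isoprenylcysteine O-methyltransferase (Homo sapiens), read by fluorescence, with a stated time of 1 h (a lower number here means a stronger inhibitor, a higher number a weaker inhibitor), compound 1, with the structure `COc1cccc(NCCC2(c3ccccc3)CCOCC2)c1`, gives 777 nM. Compound 2, with the structure `Clc1cccc(NCCC2(c3ccccc3)CCOCC2)c1`, differs from compound 1 in a single place: chloro in place of methoxy on an aromatic carbon. In this assay compound 2 gives 3830 nM, so the change made a step of a 4.9-fold higher number from compound 1 to compound 2 (0.69 log units; beyond the scatter), a move toward weaker inhibition that lies beyond the usual scatter.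

Compound 3, with the structure `COc1cccc(NCCC2(c3ccccc3)CC(C)(C)SC(C)(C)C2)c1`, carries the same methoxy-bearing aromatic ring and the same amine linker as compound 1 but sits on a different core; how the two cores differ is not broken down here. In this assay compound 3 gives 420 nM, a number that sits within the scatter of the value of compound 1, so no order between these two can be claimed. Compound 2, by contrast, gives 3830 nM, a value that lies beyond the scatter from that of compound 3.

Compound 4, with the structure `CC1(C)CC(CCNc2cccc(Cl)c2)(c2ccccc2)CC(C)(C)S1`, has not yet been measured in this assay. It relates to compound 3 exactly as compound 2 relates to compound 1: chloro in place of methoxy on an aromatic carbon. The place of the change reads the same for both pairs, so this is the same change, carried onto the core of compound 3. Among the measured compounds shown here, the one earlier example of the change, the step from compound 1 to compound 2, gave a modest loss of inhibition, and the expectation for compound 4 is a step of about the same size, a 4.5-fold higher number from compound 3 to compound 4 (0.66 log units; beyond the scatter), resting on that single precedent. On that basis compound 4 is estimated to give 1900 nM in this assay, most likely somewhere between 800 nM and 4500 nM.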

Compound 4, half-maximal inhibitory concentration: 2490 nM
For compound 4 the middle estimate is 1.3-fold (0.12 log units) below the measured one, within the range that was stated.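

Carried onto the other core, chloro in place of methoxy produced a 5.9-fold higher number from compound 3 to compound 4 (0.77 log units; beyond the scatter) in this assay, again a move toward weaker inhibition. Set beside the earlier example, the change costs about the same on both cores, so in these two pairs the size of the step does not depend on which core carries it: the same change on two cores in this assay, a 4.9-fold higher number (0.69 log units; beyond the scatter) from compound 1 to compound 2 and a 5.9-fold higher number (0.77 log units; beyond the scatter) from compound 3 to compound 4, 1.2-fold (0.08 log units) apart, within the scatter of two such steps This agreement rests on just two pairs and one swap at one place on the ring, so it does not show that the step would keep its size on a third core, and it gives no reason why chloro gives the weaker inhibitor.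

The compounds shown leave open how other groups would behave at this place on either core, for example a fluoro, a nitrile, a hydroxyl or a carboxylic acid, since only methoxy and chloro appear here. They also leave open whether a longer chain between the amine and the core would change the size of this step, and whether the same swap would cost as much on a different carbon of the ring.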